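A Chain Exchange on Compound 1

This account rests on a few compounds, and the source may have more. Where it says the series, first, only, none or still open, it means among the compounds named here.

Compound 1 (`COc1ccc(N(C)c2nc(C)nc3ccccc23)cc1OCCC[Se]C#N`) - 852 nM
Compound 2 (`Cc1nc(N(C)c2ccc([Se]C#N)c(C)c2)c2ccccc2n1`) - 13 nM

In a functional assay on HCT-116 cells (Homo sapiens) for inhibition, read by MTT assay, with a stated time of 48 h (on this read-out higher numbers stand for weaker inhibition and lower numbers for stronger inhibition), compound 1 holds the higher of the two measured numbers, and compound 2 lies well below it, beyond the usual scatter. The unmeasured compound 3 (`COc1ccc(N(C)c2nc(C)nc3ccccc23)cc1C(=O)NCC[Se]C#N`) differs from compound 1 in a single chain (a group of 8 heavy atoms (4 carbon, 2 nitrogen, 1 oxygen, 1 selenium; no ring) in place of a group of 7 heavy atoms (4 carbon, 1 nitrogen, 1 oxygen, 1 selenium; no ring), on an aromatic carbon), which sits on an aromatic carbon of a six-membered aromatic ring of carbon only, ortho to a methoxy group and meta to a large group. Among the compounds with values here, no two measured compounds differ in only one place, so no measured step guides the expectation. No change beyond the scatter is therefore expected in this assay, although this expectation is uncertain. The expected step is small (a 1.2-fold lower number from compound 1 to compound 3 (0.09 log units; within the scatter)) and remains only an estimate. Compound 3 is estimated at 700 nM as a middle value, with an expected range from 150 nM to 3000 nM for its measurement.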

Compound 3, half-maximal inhibitory concentration: 313 nM
Estimate against measurement, compound 3: 2.2-fold (0.35 log units) above; measured number inside the range.
By their numbers in this assay, from the lowest: compound 2; then compound 3; then compound 1.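

Within the data shown here, the position ortho to a methoxy group responds to a change of chain: in this assay the exchange gives a 2.7-fold lower number from compound 1 to compound 3 (0.43 log units; beyond the scatter), the first single-place step in this set. The change is modest, but it shows that the chain on this aromatic carbon can be altered while the number stays in the same general region, with the entering chain carrying 1 hydrogen-bond donor where the leaving chain has none. Nothing measured here bears on the reason for this shift.

From the compounds shown here alone, whether a longer chain or an amine at this place would move the number further remains open. Compound 2 differs from compound 3 in more than one place, so the compounds shown do not tell which of those differences accounts for the gap in their printed values.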